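The compounds below may be only part of what the source reports. "The series", "measured", "known", "first", "only" and "open" are said of these compounds alone.

Compound 2 `O=C(NC(=S)N1CCc2c(OCCCCCOc3ccc(Cl)cc3)cccc21)c1ccc(F)cc1` gives 31100 nM in an ADME assay on Huh-7 cells (Homo sapiens) for cytotoxicity (a lower number here means that less compound is tolerated, a higher number that more compound is tolerated), the highest of the three numbers, though it lies within the scatter of compound 1 `O=C(NC(=S)n1ccc2c(OCCCCCOc3ccc(Cl)cc3)cccc21)c1ccccc1`, which gives 29500 nM, and of compound 3 `O=C(NC(=S)N1CCc2c(OCCCCCOc3ccc(Cl)cc3)cccc21)c1ccc(Br)cc1`, which gives 29100 nM. Compound 4 `O=C(NC(=S)N1CCc2c(OCCCCCOc3ccc(Cl)cc3)cccc21)c1ccsc1` differs from compound 2 in one place: thiophen-3-yl in place of 4-fluorophenyl on a carbonyl carbon. Going by the values given here, the only measured single-point step, a 1.1-fold lower number from compound 2 to compound 3 (0.03 log units; within the scatter), bears on this change loosely, since it alters the same 4-fluorophenyl that now leaves, and it stayed within the scatter. Among the compounds with values here, no step exchanges the whole ring for thiophen-3-yl. Compound 4 is therefore expected to stay within the scatter of compound 2, with an estimate of 30000 nM, ranging from 15000 nM to 60000 nM, which means an expected step of a 1.0-fold lower number from compound 2 to compound 4 (0.02 log units; within the scatter).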

Compound 4, half-maximal cytotoxic concentration: > 50000 nM
Compound 4 was reported as a limit (the forecaster's own chance of this, stated with the estimate: 10%); middle value at least 1.6-fold (0.22 log units) from the limit.
By their numbers in this assay, from the lowest: compounds 3, 1 and 2 (each within the scatter of the next). At a limit, above all of these: compound 4.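

In this assay, compound 4 is reported only as a limit, > 50000 nM. Putting thiophen-3-yl in place of the halogenated phenyl rings on the carbonyl carbon gives an at least 1.6-fold higher number from compound 2 to compound 4 (0.20 log units; that floor lies within the scatter) and an at least 1.7-fold higher number from compound 3 to compound 4 (0.23 log units; that floor lies within the scatter). Compound 4 is thus the first compound shown to reach the limit, yet neither floor shows a change beyond the scatter.

Going by these compounds alone, the true size of both steps stays open, as the only figure for compound 4 is a limit: the limit of > 50000 nM in this assay, at which 1 of the 4 values shown sits. Also open is how thiophen-2-yl, pyridin-3-yl or cyclohexyl would behave on this carbonyl carbon.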